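A few compounds are considered here, and "the series" means these few. Any claim that something is new, unique, unknown or untested is made for them only; others in the source may bear on it.

In a functional assay on U-251 cells (Homo sapiens) for inhibition, read by sulforhodamine B assay, with a stated time of 48 h (on this read-out higher numbers stand for weaker inhibition of growth and lower numbers for stronger inhibition of growth), compound 2 (`Cc1ccc(-c2c(CNC(C)(C)C)c(C(=O)O)nn2-c2ccc(Cl)cc2)cc1`) gives > 629000 nM, which is a limit and not a number. Among the compounds with values here, compound 1 (`COc1ccc(-c2c(CNC(C)(C)C)c(C(=O)O)nn2-c2ccccc2)cc1`), the only other compound measured, gives > 659000 nM, also a limit, so compound 2 has no measured value to rank it. Compound 3 (`COc1ccc(-c2c(CNC(C)(C)C)c(C(=O)O)nn2-c2ccc(Cl)cc2)cc1`) differs from compound 2 by methoxy in place of methyl on an aromatic carbon, para to a large group: methoxy in place of methyl on an aromatic carbon. Within the data shown here, no measured step guides this change, so no shift beyond the scatter is expected in this assay. The expected result is an at least 1.0-fold lower number from compound 2 to compound 3 (0.01 log units; that floor lies within the scatter). Compound 3 is estimated at 604000 nM, within a range of 300000 nM to 1000000 nM.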

Compound 3, concentration for 50% growth inhibition: 498000 nM
Compound 3: the middle estimate sits 1.2-fold (0.08 log units) above what was measured; low and high end bracket the measured number.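

In this assay compound 3 is the first compound shown with a number and not a limit, and methoxy in place of methyl at this position reads as an at least 1.2-fold lower number from compound 2 to compound 3 (0.10 log units; that floor lies within the scatter), while chloro in place of hydrogen reads as an at least 1.3-fold lower number from compound 1 to compound 3 (0.12 log units; that floor lies within the scatter). Compound 2 is a limit, so the first step is only a floor: the limit of > 629000 nM in this assay, at which 1 of the 3 values shown sits. Compound 1 is also a limit, so the second step is only a floor: the limit of > 659000 nM in this assay, at which 1 of the 3 values shown sits. On these data alone, whether an ethoxy group or an amine in place of the methoxy would give a lower number stays open. So does the effect of replacing the carboxylic acid with an amide.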